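The source may hold more compounds than are shown below. What is called first, only, known or untested is meant among the compounds shown, and "the series" means these compounds.

Measured compounds:
compound 1, `CO[C@@H]1CC=C2NN(c3cc4ccccc4[nH]3)C(=O)C[C@]2(C)O1`, 14400 nM
compound 2, `CO[C@@H]1CC=C2NN(c3cc4ccccc4[nH]3)C(=O)C[C@]2(c2ccccc2)O1`, 7900 nM
compound 3, `COc1cc(OC)cc(N2NC3=CC[C@@H](OC)O[C@@]3(c3ccccc3)CC2=O)c1`, 18300 nM

All three were tested in a functional assay on DU-145 cells (Homo sapiens) for inhibition, read by sulforhodamine B assay, with a stated time of 48 h; on this read-out lower numbers stand for stronger inhibition and higher numbers for weaker inhibition. Compound 2 and compound 1 share a core and differ in one place, (methyl in place of phenyl on a saturated ring carbon), and this gave a 1.8-fold higher number from compound 2 to compound 1 (0.26 log units; within the scatter). Compound 3 carries a different core; the difference between the two cores is not broken down here. In this assay the value of compound 3 lies close to that of compound 1 and is higher than that of compound 2.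

Compound 4, `COc1cc(OC)cc(N2NC3=CC[C@@H](OC)O[C@@]3(C)CC2=O)c1`, has not been measured. It is derived from compound 3 by methyl in place of phenyl on a saturated ring carbon. Going by the values given here, this is the same kind of change as the one from compound 2 to compound 1, but the surroundings differ: in the pair of compound 2 and compound 1 the saturated ring carbon belongs to a six-membered non-aromatic ring with 1 oxygen, next to the ring oxygen, next to the ring atom that bears a fused ring, and two ring bonds from the ring atom that bears a methoxy group; in the pair of compound 3 and compound 4 it belongs to a six-membered non-aromatic ring with 2 nitrogen, two ring bonds from the ring nitrogen, three ring bonds from the ring nitrogen and three ring bonds from the ring atom that bears a large group.

The step from compound 3 to compound 4 in this assay is expected to be a 1.4-fold higher number from compound 3 to compound 4 (0.15 log units; within the scatter). Among the compounds with values here, this rests on the single measured instance of this kind of change, a 1.8-fold higher number from compound 2 to compound 1 (0.26 log units; within the scatter), tempered by the different ring surroundings. Compound 4 is therefore estimated at 26000 nM, with a likely range from 12000 nM to 60000 nM.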

Compound 4, half-maximal inhibitory concentration: 22200 nM
For compound 4 the middle estimate is 1.2-fold (0.07 log units) above the measured one, and the stated range covers the measured number.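

In this assay, methyl in place of phenyl on a saturated ring carbon gives a 1.2-fold higher number from compound 3 to compound 4 (0.08 log units; within the scatter), so on this core, as on the earlier one, the change produces no step beyond the scatter. The two cores do not differ measurably in their response to this change: the same change on two cores in this assay, a 1.8-fold higher number (0.26 log units; within the scatter) from compound 2 to compound 1 and a 1.2-fold higher number (0.08 log units; within the scatter) from compound 3 to compound 4, 1.5-fold (0.18 log units) apart, within the scatter of two such steps. Going by these compounds alone, this supports carrying the change between these two cores without expecting a clear shift in this assay, but it rests on only two pairs, and with both steps within the scatter it shows neither a real effect of the change on either core nor how the change would behave on any further core.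

Open is whether an ethyl group, a longer chain, an amine or a carboxylic acid on this saturated ring carbon would give a step beyond the scatter, since the compounds shown carry only phenyl and methyl there. Also open, from the compounds shown here alone, is whether the two cores would still agree on this change in any read-out other than this assay.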